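Cytotoxicity on Vero cells: amide replacements on a shared core

This account rests on a few compounds, and the source may have more. Where it says the series, first, only, none or still open, it means among the compounds named here.

Measured compounds:
- compound 1 `CCOCCOC(=O)Nc1cc2nc(C3CCCCC3)[nH]c2cc1N1CCCC1` gives > 100 ug/mL in an ADME assay on Vero cells (Chlorocebus sabaeus) for cytotoxicity, read by resazurin assay, with a stated time of 3 days (on this read-out lower numbers stand for stronger inhibition and higher numbers for weaker inhibition), a limit of the assay.
- compound 2 `O=C(CCc1ccccc1)Nc1cc2nc(C3CCCCC3)[nH]c2cc1N1CCCC1` gives > 100 ug/mL in this assay, a limit of the assay.
- compound 3 `CCCCNC(=O)Nc1cc2nc(C3CCCCC3)[nH]c2cc1N1CCCC1` gives > 100 ug/mL in this assay, a limit of the assay.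

Compound 3 stands only at a limit, as do the other two values, all sitting at the limit of > 100 ug/mL in this assay, at which 3 of the 3 values shown sit. The next compound, compound 4 `CCCOCC(=O)Nc1cc2nc(C3CCCCC3)[nH]c2cc1N1CCCC1`, differs from compound 3 by propoxymethyl in place of butylamino on a carbonyl carbon. The measured steps that bear on this change are a step that the two limits leave unreadable from compound 1 to compound 2, a step that the two limits leave unreadable from compound 1 to compound 3 and a step that the two limits leave unreadable from compound 2 to compound 3; none has a readable size, so no direction can be drawn from them for this assay. With every amide-side variant so far at the limit, compound 4 is expected to give 150 ug/mL (range 70 ug/mL to 400 ug/mL), most likely again reported only as a limit. The expected step is therefore a step that the limit leaves unreadable from compound 3 to compound 4.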

Compound 4, half-maximal inhibitory concentration: > 100 ug/mL
Compound 4: no number, only a limit (the forecaster's own chance of this, stated with the estimate: 85%); the middle value is on the limit's open side.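

Among the compounds shown here, no step among compound 1, compound 2, compound 3 and compound 4 can be read in this assay: the limit of > 100 ug/mL in this assay, at which 4 of the 4 values shown sit.
The compounds shown leave open whether these amide-side replacements differ at all in this assay, as each gives only a limit.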